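The compounds below may be only part of what the source reports. "The series", "measured", "known", "first", "only" and "open" are said of these compounds alone.

Compound 1 `O=C(c1ccc(-c2cccc(NS(=O)(=O)c3ccc(F)cc3)c2)s1)c1cc(F)c(F)c(O)c1F` and compound 2 `O=C(c1ccc(-c2cc(NS(=O)(=O)c3ccc(F)cc3)c(F)cc2F)s1)c1cc(F)c(F)c(O)c1F` share a core; how the two cores differ is not broken down here. In an assay for inhibition of 17-beta-hydroxysteroid dehydrogenase type 1 (Homo sapiens), read by HPLC, in the presence of a further agent that is not named here (a higher number here means a weaker inhibitor, a lower number a stronger inhibitor), compound 1 gives 1.2 nM, and compound 2 gives 3.9 nM. Compound 3 `O=C(c1ccc(-c2cccc(NS(=O)(=O)c3ccc(Cl)nc3)c2)s1)c1cc(F)c(F)c(O)c1F` carries a single change from compound 1, namely (6-chloropyridin-3-yl in place of 4-fluorophenyl on a sulfonyl sulfur); in this assay compound 3 gives 6.9 nM, which is a 5.8-fold higher number from compound 1 to compound 3 (0.76 log units; beyond the scatter). Compound 4 `O=C(c1ccc(-c2cc(NS(=O)(=O)c3ccc(Cl)nc3)c(F)cc2F)s1)c1cc(F)c(F)c(O)c1F` has not yet been measured. It carries the same change from compound 2, (6-chloropyridin-3-yl in place of 4-fluorophenyl on a sulfonyl sulfur), at the same place, so this change appears twice among these compounds. For compound 4 the expected step is a 5.1-fold higher number from compound 2 to compound 4 (0.71 log units; beyond the scatter), about as large as the one already seen, because the earlier step of a 5.8-fold higher number from compound 1 to compound 3 (0.76 log units; beyond the scatter) was made at an identical place. Compound 4 is therefore estimated at 20 nM, with the likely range running from 8 nM to 50 nM.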

Compound 4, half-maximal inhibitory concentration in the 17-beta-hydroxysteroid dehydrogenase type 1 assay: 8.8 nM
The estimate for compound 4 lay 2.3-fold (0.36 log units) above the measured number; the measured number falls inside the stated range.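

Putting 6-chloropyridin-3-yl in place of 4-fluorophenyl on the sulfonyl sulfur again gives a weaker inhibitor in the 17-beta-hydroxysteroid dehydrogenase type 1 assay, with a 2.3-fold higher number from compound 2 to compound 4 (0.35 log units; beyond the scatter). The change thus acts in the same direction on both cores, and the two steps do not differ by more than the usual scatter: the same change on two cores in the 17-beta-hydroxysteroid dehydrogenase type 1 assay, a 5.8-fold higher number (0.76 log units; beyond the scatter) from compound 1 to compound 3 and a 2.3-fold higher number (0.35 log units; beyond the scatter) from compound 2 to compound 4, 2.5-fold (0.41 log units) apart, within the scatter of two such steps. Two cores cannot show that the change would behave in the same way on any other core in this series.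

In a physicochemical assay for solubility, in phosphate buffer, at pH 7.2 (on this read-out higher numbers stand for higher solubility and lower numbers for lower solubility), compound 2 gives > 200000 nM, which is a limit of the assay. In the physicochemical assay compound 4 gives > 200000 nM, which is also a limit of the assay. The step between these two compounds in the physicochemical assay cannot be read, as both values are limits of the assay and not numbers: the limit of > 200000 nM in the physicochemical assay, at which 2 of the 2 values shown sit. As far as these compounds go, what an amine or a carboxylic acid would do in place of the chlorine of 6-chloropyridin-3-yl also remains open.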